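A few compounds are considered here, and "the series" means these few. Any claim that something is new, unique, unknown or untested is made for them only; others in the source may bear on it.

In a functional assay on MCF7 cells (Homo sapiens) for cytotoxicity, read by MTT assay, with a stated time of 48 h (on this read-out lower numbers stand for stronger inhibition and higher numbers for weaker inhibition), the three measured compounds stand as follows:

Compound 1 `Cc1ccc(S(=O)(=O)/N=C(/CCNC2=CC(=O)c3ccccc3C2=O)Nc2ccc(F)cc2)cc1`: 4260 nM
Compound 2 `Cc1ccc(S(=O)(=O)/N=C(/CCNC2=CC(=O)c3ccccc3C2=O)Nc2ccccc2I)cc1`: 15500 nM
Compound 3 `COc1ccc(N/C(CCNC2=CC(=O)c3ccccc3C2=O)=N\S(=O)(=O)c2ccc(C)cc2)cc1OC`: 12300 nM

Compound 3 thus holds the second highest number of the three. Its nearest neighbour is compound 2, and the difference between them, a 1.3-fold lower number from compound 2 to compound 3 (0.10 log units; within the scatter), lies within the scatter, so no order can be read between those two. Compound 1 stands clearly apart, with a 2.9-fold higher number from compound 1 to compound 3 (0.46 log units; beyond the scatter) marking a step beyond the scatter.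

Compound 4 `Cc1ccc(S(=O)(=O)/N=C(/CCNC2=CC(=O)c3ccccc3C2=O)Nc2cc(F)c(F)c(F)c2)cc1` differs from compound 3 in one place: 3,4,5-trifluorophenyl in place of 3,4-dimethoxyphenyl on an amine nitrogen. Going by the values given here, the only measured step that bears on it is the one from compound 1 to compound 3, since there a fluorine-bearing aryl group on the same nitrogen was exchanged for the 3,4-dimethoxyphenyl group, and the number rose by a 2.9-fold higher number from compound 1 to compound 3 (0.46 log units; beyond the scatter). The reverse exchange, toward a fluorinated aryl group, suggests that the number should fall again, though the new group carries three fluorines rather than one, so the size cannot be matched exactly. Compound 4 is therefore expected to give a modestly lower number than compound 3, the estimated step being a 1.8-fold lower number from compound 3 to compound 4 (0.24 log units; within the scatter). The estimate for compound 4 in this assay is 7000 nM, within a range from 3000 nM to 18000 nM.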

Compound 4, half-maximal inhibitory concentration: 6610 nM
The estimate for compound 4 lay 1.1-fold (0.02 log units) above the measured number; the range from low to high includes it.
By their numbers in this assay, from the lowest: compounds 1, 4, 3 and 2 (each within the scatter of the next, the first and the last beyond it).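

In this assay the 3,4,5-trifluorophenyl group on the amine nitrogen cannot be told apart from the 4-fluorophenyl group (a 1.6-fold higher number from compound 1 to compound 4 (0.19 log units; within the scatter)), so on this evidence the further fluorines bring no readable gain or loss. It also cannot be told apart from the 3,4-dimethoxyphenyl group (a 1.9-fold lower number from compound 3 to compound 4 (0.27 log units; within the scatter)), which means compound 4 sits within the scatter of both compound 1 and compound 3, although those two stand apart, and the earlier gap between a fluorinated and a dimethoxylated aryl group does not hold as a clean divide. Only the comparison with the 2-iodophenyl group goes beyond the scatter (a 2.3-fold lower number from compound 2 to compound 4 (0.37 log units; beyond the scatter)), so both fluorinated aryl groups now stand clear of the 2-iodophenyl group, while compound 3 does not, and nothing shown explains these differences.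

The compounds shown leave open how an unsubstituted phenyl ring, a trifluoromethyl-bearing phenyl ring or a benzyl group on this nitrogen would compare. They also leave open whether a saturated ring such as cyclohexyl could take the place of the aryl group at all.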